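Formyl on the ring amine: expected maximal response for compound 4

The source may report more compounds than this note shows. Statements on the series, on what has been measured and on what is new or still open speak of the compounds shown alone.

Compound 3 `O=C(N[C@H]1CN(S(=O)(=O)c2ccccc2)C[C@@H]1C(=O)N[C@H]1CCCNC1)c1cc(-c2ccccc2Cl)on1` is the reference point for this step. In a functional assay on HEK293 cells for agonist activity at growth hormone secretagogue receptor type 1 (Homo sapiens), read by HTRF and inositol phosphate accumulation, with a stated time of 90 min, in the presence of a further agent that is not named here (a lower number here means a smaller maximal response, a higher number a larger maximal response), compound 3 gives 98%. Compound 1 `Cc1ccc2[nH]c(C(=O)N[C@H]3CN(S(=O)(=O)c4ccccc4)C[C@@H]3C(=O)N[C@H]3CCCNC3)cc2c1` gives 98% and compound 2 `O=C(N[C@H]1CN(S(=O)(=O)c2ccccc2)C[C@@H]1C(=O)N[C@H]1CCCNC1)c1cc(-c2ccc(Cl)cc2)on1` gives 91%. The measured steps all concern the acyl group on the carbonyl carbon: no change at the digits printed from compound 1 to compound 3 (within the scatter), a number 7 percentage points lower from compound 1 to compound 2 (within the scatter) and a number 7 percentage points higher from compound 2 to compound 3 (within the scatter). Compound 3 is thus level with compound 1 at the digits shown, and compound 2 lies within the scatter of both; all three numbers sit near a full response.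

Compound 4 `O=CN1CCC[C@H](NC(=O)[C@H]2CN(S(=O)(=O)c3ccccc3)C[C@@H]2NC(=O)c2cc(-c3ccccc3Cl)on2)C1` differs from compound 3 in one place: formyl in place of hydrogen on an amine nitrogen in a ring. None of the three measured steps touches the amine nitrogen in the six-membered non-aromatic ring; the only variation seen so far, at the acyl group, left the maximal response unchanged within the scatter. Going by the values given here, there is therefore no direct precedent for this change, and the spread among the measured compounds gives no direction. The expectation is that compound 4 stays in the range of a near-full response, with a wider uncertainty on the low side, so the step of a number 10 percentage points lower from compound 3 to compound 4 (within the scatter) is estimated to be small. For compound 4 the expected value is 88%, within 55% to 105%.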

Compound 4, largest response reached (Emax), in percent of the reference or control that the assay uses: 90%
Estimate against measurement, compound 4: 2 percentage points below; measured number inside the range.
By their numbers in this assay, from the lowest: compounds 4, 2, 1 and 3 (each within the scatter of the next).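

In this assay, going by these compounds alone, the step of a number 8 percentage points lower from compound 3 to compound 4 (within the scatter) is the first one at the amine nitrogen in the six-membered non-aromatic ring, as all earlier steps concerned the acyl group on the carbonyl carbon. It shows that this nitrogen need not carry hydrogen for the maximal response to stay within the scatter of the parent, at least with formyl on the nitrogen and the 5-(2-chlorophenyl)-1,2-oxazol-3-yl acyl group of compound 3 on the other side of the molecule. No measurement shown here gives a reason for this tolerance, so the result stands as an observation on one pair of compounds.

On these data alone, one small acyl group on this nitrogen says little about larger or different groups, so it remains open whether acetyl, benzoyl, methyl, a longer alkyl chain or a chain ending in a carboxylic acid would hold the response in the same way. As far as these compounds go, it is also open whether formyl at this nitrogen is equally tolerated with the other acyl groups, the 5-methyl-1H-indol-2-yl of compound 1 and the 5-(4-chlorophenyl)-1,2-oxazol-3-yl of compound 2.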